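Swapping one halogen for another on a shared core

The source may report more compounds than this note shows. Statements on the series, on what has been measured and on what is new or still open speak of the compounds shown alone.

Of the compounds shown here, three built on one shared core have been measured in a functional assay on cells for agonist activity at uracil nucleotide/cysteinyl leukotriene receptor (Homo sapiens), read by fluorescence and calcium flux; a higher number here means that more compound is needed for the effect, a lower number that less compound is needed. Compound 1 `O=C(O)CCc1c(C(=O)O)[nH]c2cc(C(F)(F)F)cc(C(F)(F)F)c12` gives 17100 nM. Compound 2 `O=C(O)CCc1c(C(=O)O)[nH]c2cc(Cl)c(F)c(Cl)c12` gives 52000 nM. Compound 3 `O=C(O)CCc1c(C(=O)O)[nH]c2cccc(Br)c12` gives 45500 nM. Among these three numbers compound 3 stands second highest: its nearest neighbour is compound 2, whose number lies within the usual scatter of it, while compound 1 lies beyond the scatter with a lower number. A further compound, compound 4 `O=C(O)CCc1c(C(=O)O)[nH]c2cccc(I)c12`, has not yet been measured in this assay. It differs from compound 3 by iodo in place of bromo on an aromatic carbon. Among the compounds with values here, no step between two measured compounds that differ in only one place is available, so the size of this change has to be judged from the change itself. Replacing one halogen by a heavier one is expected to move the number little, perhaps slightly downward, and quite possibly not beyond the scatter. Compound 4 is therefore expected to give 35000 nM, with a range from 12000 nM to 100000 nM. The estimated step of a 1.3-fold lower number from compound 3 to compound 4 (0.11 log units; within the scatter) is expected to stay close to the usual scatter.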

Compound 4, half-maximal effective concentration: 36800 nM
Beside the measured number, compound 4's estimate is 1.1-fold (0.02 log units) below it; measured number inside the range.
By their numbers in this assay, from the lowest: compound 1; then compounds 4, 3 and 2 (each within the scatter of the next).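

Within the data shown here, this pair is the first to differ in one place only, so a change at this aromatic carbon can now be read directly: in this assay, iodo in place of bromo gives a 1.2-fold lower number from compound 3 to compound 4 (0.09 log units; within the scatter), and the step is the only one available. Bromo and iodo therefore cannot be told apart at this position in this read-out. No measurement shown offers an explanation for this result.

The compounds shown leave open whether fluoro or chloro alone at this position would also stay within the scatter of bromo and iodo, and whether a non-halogen group such as an amine or a methoxy would move the number. They also leave open how a longer chain in place of the acid-bearing side chain of the shared core would act.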